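The compounds below may be only part of what the source reports. "The series", "measured", "known", "first", "only" and "open" are said of these compounds alone.

Measured so far in a functional assay on PC-3 cells (Homo sapiens) for antiproliferative activity, read by MTT assay, with a stated time of 24 h; a higher number here means a weaker inhibitor, a lower number a stronger inhibitor:
Compound 1 `c1ccc(-c2noc(-c3ccncc3)n2)cc1`: > 1000000 nM
Compound 2 `COc1ccc(-c2noc(-c3ccncc3)n2)cc1OC1CCCC1`: > 1000000 nM
Compound 3 `Fc1ccc(-c2nc(-c3ccccc3)no2)cc1`: > 1000000 nM

Every entry here is a limit of the assay and not a number, and together they make up (the limit of > 1000000 nM in this assay, at which 3 of the 3 values shown sit). Compound 2 gives > 1000000 nM, which is a limit.

Compound 4 `COc1ccc(-c2noc(-c3ccc(O)cc3)n2)cc1OC1CCCC1` keeps the rest of compound 2 but has 4-hydroxyphenyl in place of pyridin-4-yl on an aromatic carbon. Within the data shown here, no pair of measured compounds yet shows the size of any single change in this assay. A modest shift toward a lower number, toward a stronger inhibitor, is the expectation, and compound 4 may well remain at the limit. The expected change is an at least 2.5-fold lower number from compound 2 to compound 4 (0.39 log units; beyond the scatter). Compound 4 is estimated at 400000 nM, with an expected range of 50000 nM to 1000000 nM.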

Compound 4, half-maximal inhibitory concentration: 162000 nM
For compound 4 the middle estimate is 2.5-fold (0.39 log units) above the measured one; low and high end bracket the measured number.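

Among the compounds shown, only compound 4 gives a number rather than a limit in this assay, so a change at this position on the shared core can register in the read-out. Putting 4-hydroxyphenyl in place of pyridin-4-yl gives an at least 6.1-fold lower number from compound 2 to compound 4 (0.79 log units; beyond the scatter). That size is only a minimum because compound 2 sits at a limit: the limit of > 1000000 nM in this assay, at which 3 of the 4 values shown sit.

Still open, as far as these compounds go, is which part of the swap counts, the carbon-only ring or its hydroxy group, as both enter together. From the compounds shown here alone, how an amine or a carboxylic acid in place of that hydroxy group would compare is also open.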